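The source may report more compounds than this note shows. Statements on the series, on what has been measured and on what is new or still open speak of the compounds shown alone.

Values in a functional assay on T-24 cells (Homo sapiens) for antiproliferative activity, read by MTT assay, with a stated time of 48 h (on this read-out lower numbers stand for stronger inhibition and higher numbers for weaker inhibition), so far are these:

- compound 1 `COc1ccccc1NC(=O)Nc1cccc(CNc2nccnc2Cl)c1` gives 10400 nM
- compound 2 `O=C(Nc1cccc(Cl)c1)Nc1cccc(CNc2nccnc2Cl)c1` gives 6810 nM
- compound 3 `O=C(Nc1cccc(CNc2nccnc2Cl)c1)Nc1ccccc1F` gives 7450 nM

In this assay the three compounds form a single tight group, and compound 3 stands inside it, within the scatter of both others. The measured steps to and from it are a 1.4-fold lower number from compound 1 to compound 3 (0.14 log units; within the scatter) and a 1.1-fold higher number from compound 2 to compound 3 (0.04 log units; within the scatter) on either side.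

The next compound is compound 4 `O=C(Nc1cccc(CNc2nccnc2Cl)c1)Nc1ccc(Cl)cc1Br`, which has 2-bromo-4-chlorophenyl in place of 2-fluorophenyl on an amide-type nitrogen. Within the data shown here, the steps that bear on this change are those that exchange the aromatic group on that same nitrogen. These are a 1.5-fold lower number from compound 1 to compound 2 (0.18 log units; within the scatter) and the two already given, and none of them leaves the scatter. Among the measured compounds shown here, no measured compound carries a bromo group or two halogens on that ring, so the data do not test this particular exchange directly. They offer no ground for expecting a large move in either direction.

The expected change, a 1.2-fold lower number from compound 3 to compound 4 (0.09 log units; within the scatter), is therefore no step beyond the scatter. For compound 4 the estimated value is 6000 nM, with an expected range from 2500 nM to 14000 nM as its bounds.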

Compound 4, half-maximal inhibitory concentration: 6650 nM
For compound 4 the middle estimate is 1.1-fold (0.04 log units) below the measured one, within the range that was stated.
By their numbers in this assay, from the lowest: compounds 4, 2, 3 and 1 (each within the scatter of the next).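

In this assay, among these compounds, compound 4 puts two halogens, a bromo and a chloro group, on the aromatic ring on the amide-type nitrogen, which no earlier compound did, and the result stays in the same tight group: there is (a 1.1-fold lower number from compound 3 to compound 4 (0.05 log units; within the scatter)) and (a 1.0-fold lower number from compound 2 to compound 4 (0.01 log units; within the scatter)) and (a 1.6-fold lower number from compound 1 to compound 4 (0.19 log units; within the scatter)). All four aromatic groups shown on this nitrogen, 2-methoxyphenyl, 3-chlorophenyl, 2-fluorophenyl and 2-bromo-4-chlorophenyl, therefore give values that do not separate, so among these compounds this position has so far tolerated the added halogen without a change that can be read, and no compound goes against that. Nothing in the available information explains this insensitivity.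

The compounds shown leave open whether a group of a different kind on that ring, such as an amine or a carboxylic acid, or a longer chain placed on that nitrogen in place of the aromatic ring, would move the value out of this group. They also leave open whether exchanging the chloro group on the shared core would do so, since every compound here carries it unchanged.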